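Ethyl in place of chloro on compound 1

A few compounds are considered here, and "the series" means these few. Any claim that something is new, unique, unknown or untested is made for them only; others in the source may bear on it.

Within the data shown here, in an ADME assay on Vero cells (Chlorocebus sabaeus) for cytotoxicity, read by MTT assay, with a stated time of 96 h (a higher number here means that more compound is tolerated, a lower number that less compound is tolerated), compound 1 (`COc1cc(NCc2ccc(Cl)s2)ccc1-c1cnco1`) gives 53800 nM and stands lowest of the two numbers so far. Compound 2 (`COc1cc(/N=C/c2ccc(F)cc2)ccc1-c1cnco1`) at 325000 nM lies higher, beyond the scatter. Compound 3 (`CCc1ccc(CNc2ccc(-c3cnco3)c(OC)c2)s1`) carries ethyl in place of chloro on an aromatic carbon, 5-chlorothiophen-2-yl to 5-ethylthiophen-2-yl (ethyl in place of chloro on an aromatic carbon). Among the measured compounds shown here, no measured pair shows this change. In this assay no step beyond the scatter is expected. The expected change is a 1.1-fold lower number from compound 1 to compound 3 (0.03 log units; within the scatter) and stays within the scatter. Compound 3 is estimated at 50000 nM (range 20000 nM to 130000 nM).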

Compound 3, half-maximal cytotoxic concentration: 13600 nM
The estimate for compound 3 lay 3.7-fold (0.57 log units) above the measured number; the whole stated range lies above it.
By their numbers in this assay, from the lowest: compound 3; then compound 1; then compound 2.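

In this assay this position is not indifferent to its substituent: ethyl in place of chloro, on the aromatic carbon next to the ring sulfur, gives a 4.0-fold lower number from compound 1 to compound 3 (0.60 log units; beyond the scatter) and so leaves less compound tolerated. Among these compounds, this is the first step read at one position, and it is a modest one. No measurement on hand bears on the origin of this step.

A single pair gives no trend at this carbon. As far as these compounds go, whether a longer chain such as propyl, or an amine, would move the number further stays open.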